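Estimating compound 4 without a measured starting point

A few compounds are considered here, and "the series" means these few. Any claim that something is new, unique, unknown or untested is made for them only; others in the source may bear on it.

In a functional assay (Platelet, plasma) for inhibition, with Homo sapiens as the target (a lower number here means a stronger inhibitor, a higher number a weaker inhibitor), compound 3 (`N#Cc1cc2c(nc1N1CCC(C(=O)NS(=O)(=O)C(F)(F)c3ccccc3)CC1)COC2=O`) is recorded as "not determined" (no result reported) and so offers no number to step from. The change to compound 4 (`Cc1ccc(CS(=O)(=O)NC(=O)C2CCN(c3nc4c(cc3C#N)C(=O)OC4)CC2)cc1`) puts 4-methylbenzyl in place of difluoro(phenyl)methyl on a sulfonyl sulfur. The nearest evidence lies elsewhere. Compound 1 (`N#Cc1cc2c(nc1N1CCC(C(=O)NS(=O)(=O)Cc3cccc(F)c3)CC1)COC2=O`) gives 70500 nM in this assay and compound 2 (`N#Cc1cc2c(nc1N1CCC(C(=O)NS(=O)(=O)Cc3ccc(C(F)(F)F)cc3)CC1)COC2=O`) gives 15900 nM in the same test. That modest step (a 4.4-fold lower number from compound 1 to compound 2 (0.65 log units; beyond the scatter)) is the only measured one bearing on this place, so compound 4 is expected to fall in the same region, though no size or direction of step from compound 3 can be stated. For compound 4 the estimated value is 30000 nM (expected range 10000 nM to 85000 nM).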

Compound 4, half-maximal inhibitory concentration: 4280 nM
For compound 4 the middle estimate is 7.0-fold (0.85 log units) above the measured one, outside the stated range (below it).
By their numbers in this assay, from the lowest: compound 4; then compound 2; then compound 1.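

In this assay, 4-methylbenzyl on the sulfonyl sulfur gives the lowest number yet, with a 3.7-fold lower number from compound 2 to compound 4 (0.57 log units; beyond the scatter) and a 16-fold lower number from compound 1 to compound 4 (1.22 log units; beyond the scatter). Among these three compounds, the one without fluorine on its ring therefore stands lowest, so fluorine on that ring is not needed for a low number here. No measurement shown gives a reason for these steps. Compound 3 has no number, so the steps from it cannot be read. On these data alone, how an amine or a carboxylic acid on the ring, or a longer chain in place of 4-methylbenzyl, would read stays open.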